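The source may report more compounds than this note shows. Statements on the series, on what has been measured and on what is new or still open speak of the compounds shown alone.

Of the compounds shown here, two built on the same core have been measured in a physicochemical assay for solubility, read by spectrophotometry, measured as kinetic solubility, at pH 8, tested at 500 uM; a lower number here means a less soluble compound, a higher number a more soluble compound. Compound 1 `CN(C)S(=O)(=O)c1ccccc1Nc1cc(-c2ccc3ccn(C)c3c2)c2nccnc2c1` carries a dimethylsulfamoyl-substituted phenyl on the shared amine, and in this assay compound 1 gives 2 ug/mL. Compound 2 `CC(=O)N1CCC(NC(=O)c2ccncc2Nc2cc(-c3ccc4ccn(C)c4c3)c3nccnc3c2)CC1` instead carries a pyridine ring bearing a carboxamide to 1-acetylpiperidin-4-yl, and in this assay compound 2 gives 213 ug/mL. Of the two numbers, compound 2 stands highest, and its gap to compound 1 is well beyond the scatter of repeated measurements.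

Compound 3 `CC(=O)N1CCC(NC(=O)c2ccncc2Nc2cc(-c3ccc4ccn(C)c4c3)c3nccnc3c2)C1` has not yet been measured. It differs from compound 2 in one place only: 1-acetylpyrrolidin-3-yl in place of 1-acetylpiperidin-4-yl on an amide-type nitrogen. The six-membered ring shrinks to a five-membered one, while the acetyl group, the amide link and the rest of the molecule stay as they are. Among the measured compounds shown here, no measured pair shows what such a ring contraction does here, so the expectation rests on compound 2 alone. The step from compound 2 to compound 3 is expected to be small, a 1.1-fold lower number from compound 2 to compound 3 (0.05 log units; within the scatter), and not beyond the usual scatter in either direction. Compound 3 is therefore estimated at 190 ug/mL, with a range from 90 ug/mL to 250 ug/mL.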

Compound 3, solubility: 253 ug/mL
For compound 3 the middle estimate is 1.3-fold (0.12 log units) below the measured one; measured number above the stated range.
By their numbers in this assay, from the lowest: compound 1; then compounds 2 and 3 (each within the scatter of the next).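

In this assay, putting 1-acetylpyrrolidin-3-yl in place of 1-acetylpiperidin-4-yl on the amide-type nitrogen gives a 1.2-fold higher number from compound 2 to compound 3 (0.07 log units; within the scatter), so this measurement cannot tell the two compounds apart. Among the compounds shown here, this is the first pair that differs in one place only, and it shows that a five-membered ring can replace the six-membered one at this position without a reading that stands clear of the scatter, at least when the acetyl group and the amide link stay unchanged. No supporting data accompany this pair that could explain the result.

Both rings in this pair carry the same acetyl group on their nitrogen, so the pair says nothing about how a free ring amine, a methanesulfonyl group or a carboxylic acid would read at that place. It also leaves open whether the same insensitivity would hold if the ring were replaced altogether, for example by an open chain such as 2-methoxyethyl on the amide-type nitrogen.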